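The compounds below may be only part of what the source reports. "The series", "measured", "known", "first", "only" and "open" are said of these compounds alone.

Two compounds share one core and differ only in the group carried on a nitrogen on an aromatic ring. Compound 1 `CN(C)c1ccc(C(=O)N2CCCCc3ccccc32)c(Cl)c1` gives 18 nM in an assay on HeLa cells for binding affinity to Vasopressin V2 receptor (Homo sapiens); on this read-out lower numbers stand for stronger inhibition and higher numbers for weaker inhibition. Compound 2 `CCCCNc1ccc(C(=O)N2CCCCc3ccccc32)c(Cl)c1` gives 22 nM in this assay. Going by the values given here, the single known step, a 1.2-fold higher number from compound 1 to compound 2 (0.09 log units; within the scatter), shows that swapping the group on that nitrogen left the number essentially where it was. Among the compounds with values here, on the numbers so far compound 2 is the higher of the two, yet its gap to compound 1 lies within the scatter, so nothing separates them.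

Compound 3 `C=CCNc1ccc(C(=O)N2CCCCc3ccccc32)c(Cl)c1` is the next step from compound 2: vinyl in place of propyl on a saturated chain carbon bound to a nitrogen on an aromatic ring. Within the data shown here, the one measured step that bears on this kind of change, a 1.2-fold higher number from compound 1 to compound 2 (0.09 log units; within the scatter), was within the scatter, so the expected step of no change at the digits printed from compound 2 to compound 3 (within the scatter) is also nothing beyond the scatter. For compound 3 the estimate in this assay is 22 nM, expected to fall between 10 nM and 50 nM.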

Compound 3, half-maximal inhibitory concentration: 5.9 nM
The estimate for compound 3 lay 3.7-fold (0.57 log units) above the measured number, and the stated range ends above it.
By their numbers in this assay, from the lowest: compound 3; then compounds 1 and 2 (each within the scatter of the next).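

The earlier pair suggested that the group on this nitrogen hardly mattered, but in this assay the step of a 3.7-fold lower number from compound 2 to compound 3 (0.57 log units; beyond the scatter) shows that it can: butylamino to allylamino moves the number beyond the scatter. The step of a 3.1-fold lower number from compound 1 to compound 3 (0.48 log units; beyond the scatter) points the same way, so allylamino stands apart from both dimethylamino and butylamino, which remain within the scatter of each other. Nothing available explains why this change lowers the number.

The change shortens the chain and adds a double bond at once, so the compounds shown cannot say which of the two matters. A propylamino group would keep the shorter chain without the double bond, while a propargylamino group would show how a triple bond compares at the same place.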